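From carboxy to dimethylamino: a step down expected

The source may report more compounds than this note shows. Statements on the series, on what has been measured and on what is new or still open speak of the compounds shown alone.

Measured in a physicochemical assay for solubility, read by nephelometry; a higher number here means a more soluble compound, a lower number a less soluble compound:
- Compound 1 `CC1(C)C(=O)N(c2ccc(SC(F)(F)F)cc2)C(=O)N1Cc1ccncc1`: < 0.02 ug/mL, a limit of the assay
- Compound 2 `CC1(C)C(=O)N(c2ccc(SC(F)(F)F)cc2)C(=O)N1Cc1ccnc(N2CCNCC2)c1`: < 0.024 ug/mL, a limit of the assay
- Compound 3 `CC1(C)C(=O)N(c2ccc(SC(F)(F)F)cc2)C(=O)N1Cc1ccnc(C(=O)O)c1`: 0.142 ug/mL

Of these three results, only compound 3 has a true number, and it stands highest of the series in this assay, clear of both limits. The next compound, compound 4 `CN(C)c1cc(CN2C(=O)N(c3ccc(SC(F)(F)F)cc3)C(=O)C2(C)C)ccn1`, carries dimethylamino in place of carboxy on an aromatic carbon, with the change lying next to the ring nitrogen.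

Within the data shown here, two measured steps bear on this change. One is an at least 7.1-fold higher number from compound 1 to compound 3 (0.85 log units; beyond the scatter), with carboxy in place of hydrogen. The other is an at least 5.9-fold higher number from compound 2 to compound 3 (0.77 log units; beyond the scatter), with carboxy in place of piperazin-1-yl. Both lie beyond the scatter, and both give only a minimum size. A third step, a step that the two limits leave unreadable from compound 1 to compound 2, gives no size at all. Among the measured compounds shown here, no measured compound carries dimethylamino, so the comparison is indirect.

Compound 4 lacks carboxy, as compound 2 does, so the gain seen in an at least 5.9-fold higher number from compound 2 to compound 3 (0.77 log units; beyond the scatter) is expected to be lost again. The expected step is a 7.1-fold lower number from compound 3 to compound 4 (0.85 log units; beyond the scatter), downward and beyond the scatter. For compound 4 the estimated value is 0.02 ug/mL, with an expected range of 0.008 ug/mL to 0.06 ug/mL, and the assay may well report only a limit.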

Compound 4, solubility: < 0.022 ug/mL
Compound 4 ended at the assay's limit; the forecaster's own chance of this, stated with the estimate: 70%; the middle value lies beyond the limit too.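

In this assay compound 4 gives < 0.022 ug/mL, which is a limit of the assay and not a number. Dimethylamino in place of carboxy, on an aromatic carbon next to the ring nitrogen, gives an at least 6.4-fold lower number from compound 3 to compound 4 (0.80 log units; beyond the scatter), so a group with the same count of 3 heavy atoms does not keep compound 3's reading, and this adds a third group at this place, after hydrogen and piperazin-1-yl, that stays at a limit while carboxy alone stands clear of one. The steps from compound 1 and from compound 2 to compound 4 cannot be read, as both ends of each are limits, so dimethylamino cannot be ordered against hydrogen or piperazin-1-yl: the limit of < 0.022 ug/mL in this assay, at which 1 of the 4 values shown sits.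

The compounds shown leave open whether a primary amide or a methyl ester at this place would also stand clear of the limit, or whether only the carboxylic acid does. They also leave open how far the true values of compound 1, compound 2 and compound 4 lie under their limits, and whether any of the three differs from the others.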